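Chloro to iodo on the core: an open question

The compounds below may be only part of what the source reports. "The series", "measured", "known", "first", "only" and "open" are said of these compounds alone.

The series shares a core with two methoxy groups and a 4-methoxyphenyl group; the compounds differ in the group on the ring nitrogen and in the group on the aromatic carbon two atoms from it. Compound 1 `COc1ccc(-c2cc(=O)c3c(OC)cc(OC)cc3n2C)cc1` carries a methyl on the ring nitrogen and hydrogen on that carbon. In a functional assay on SEM cells (Homo sapiens) for antiproliferative activity, with a stated time of 72 h (a higher number here means that more compound is needed for the effect, a lower number that less compound is needed), compound 1 gives 26000 nM. Compound 2 `COc1ccc(-c2c(Cl)c(=O)c3c(OC)cc(OC)cc3n2S(=O)(=O)c2ccc(OC)cc2)cc1` carries a (4-methoxyphenyl)sulfonyl group on the ring nitrogen and a chloro on the aromatic carbon. Within the data shown here, for compound 2 in this assay the outcome is "not determined" (no result reported), so compound 2 stands on no number at all, and the only figure is the one for compound 1.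

Compound 3 `COc1ccc(-c2c(I)c(=O)c3c(OC)cc(OC)cc3n2S(=O)(=O)c2ccc(OC)cc2)cc1` differs from compound 2 by iodo in place of chloro on an aromatic carbon. Among the measured compounds shown here, no measured pair shows what this kind of change does in this assay; with nothing to lean on, the expectation is a step of no more than the usual scatter in either direction from wherever compound 2 would fall. For compound 3 the half-maximal effective concentration in this assay is estimated at 10000 nM, with a range from 1500 nM to 60000 nM.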

Compound 3, half-maximal effective concentration: 5520 nM
Estimate against measurement, compound 3: 1.8-fold (0.26 log units) above, within the range that was stated.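

No new step can be read: compound 2 has no number in this assay, so the chloro to iodo change between compound 2 and compound 3 has no size. The compounds shown leave open what iodo in place of chloro does on this carbon. No evidence bears on the result.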